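A few compounds are considered here, and "the series" means these few. Any claim that something is new, unique, unknown or untested is made for them only; others in the source may bear on it.

Of the compounds shown here, three built on one shared core have been tested in a functional assay on HeLa cells (Homo sapiens) for antiproliferative activity, read by MTT assay, with a stated time of 48 h; a lower number here means a stronger inhibitor, a higher number a weaker inhibitor. Compound 1 `Cn1c(N)c(-c2nc3ccccc3[nH]2)c2nc(C#N)c(C#N)nc21` is the simplest of them. In this assay compound 1 reaches only a limit, > 50000 nM, so no number is known for it. Compound 2 `CCN(CC)CCn1c(N)c(-c2nc3ccccc3[nH]2)c2nc(C#N)c(C#N)nc21` gives 11600 nM in this assay, and compound 3 `CN(C)CCCn1c(N)c(-c2nc3ccccc3[nH]2)c2nc(C#N)c(C#N)nc21` gives 25900 nM. Of the two measured numbers compound 3 is the higher, its nearest neighbour being compound 2 with a 2.2-fold higher number from compound 2 to compound 3 (0.35 log units; beyond the scatter). The chains themselves gave an at least 4.3-fold lower number from compound 1 to compound 2 (0.63 log units; beyond the scatter) and an at least 1.9-fold lower number from compound 1 to compound 3 (0.28 log units; that floor lies within the scatter).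

Compound 4 `N#Cc1nc2c(-c3nc4ccccc4[nH]3)c(N)n(CCCNc3ccccc3)c2nc1C#N` has not yet been measured. It differs from compound 3 by anilino in place of dimethylamino on a saturated chain carbon, three bonds along the chain from an aromatic nitrogen. Among the measured compounds shown here, the only measured step at a nearby place is the one from compound 2 to compound 3, where diethylamino was exchanged for dimethylamino and the step was modest; no measured step swaps such a group for anilino. The steps from compound 1 show that the chain matters, but they give no direction for this exchange. A modest step in either direction, or none beyond the scatter, is therefore expected in this assay. Compound 4 is estimated to give 20000 nM, between 6000 nM and 60000 nM, which means an expected step of a 1.3-fold lower number from compound 3 to compound 4 (0.11 log units; within the scatter).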

Compound 4, half-maximal inhibitory concentration: 26300 nM
The estimate for compound 4 lay 1.3-fold (0.12 log units) below the measured number; the range from low to high includes it.
By their numbers in this assay, from the lowest: compound 2; then compounds 3 and 4 (each within the scatter of the next). At a limit, above all of these: compound 1.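

In this assay, anilino in place of dimethylamino on a saturated chain carbon, three bonds along the chain from an aromatic nitrogen, adds a six-membered aromatic ring of carbon only and a hydrogen-bond donor, yet the read-out does not separate the two compounds: a 1.0-fold higher number from compound 3 to compound 4 (0.01 log units; within the scatter). For this one pair, then, a much larger group at the end of the chain leaves the number where it was, while the gap to the diethylamino compound remains, as a 2.3-fold higher number from compound 2 to compound 4 (0.36 log units; beyond the scatter), a step that exchanges the end group and changes the chain together. The remaining step, an at least 1.9-fold lower number from compound 1 to compound 4 (0.27 log units; that floor lies within the scatter), gives only a floor, because compound 1 gives a limit and no number: the limit of > 50000 nM in this assay, at which 1 of the 4 values shown sits.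

The compounds shown leave open whether the gap to compound 2 follows the end group or the chain length, which a 3-(diethylamino)propyl chain on the shared core would help to separate. They also leave open whether this end of the chain responds to any change at all, for instance a morpholine in place of anilino or a chlorine on the anilino ring.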